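The compounds below may be only part of what the source reports. "The series", "measured", "known", "first", "only" and "open" are said of these compounds alone.

Working notes on the series, all read in a functional assay on PC-3 cells (Homo sapiens) for antiproliferative activity, read by luminescence, with a stated time of 96 h; on this read-out lower numbers stand for stronger inhibition and higher numbers for weaker inhibition. Compound 1 (`CC1(C)Oc2cc(NS(=O)(=O)C3CCCCC3)ccc2NC1=O`) gives 30400 nM, compound 2 (`CC1(C)Oc2cc(NS(=O)(=O)c3ccccc3)ccc2NC1=O`) gives 40100 nM, and compound 3 (`COc1cc2c(cc1NS(=O)(=O)c1cc(Br)ccc1OC)OC(C)(C)C(=O)N2`) gives 17200 nM. Compound 3 therefore stands within the scatter of compound 1, while its lower number against compound 2 lies beyond the scatter.

The next point is compound 4 (`COc1ccc(Br)cc1S(=O)(=O)Nc1cc2c(cc1O)NC(=O)C(C)(C)O2`). The change is hydrogen in place of methyl on an oxygen on an aromatic ring, or methoxy to hydroxy.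

Within the data shown here, no measured pair covers this change. Among the measured compounds shown here, the only measured step is a 1.3-fold higher number from compound 1 to compound 2 (0.12 log units; within the scatter), with phenyl in place of cyclohexyl on a sulfonyl sulfur. For the measured compounds named here, that step lies within the scatter and sits at a different place, so it bears only indirectly, as the one single-place change seen so far in this assay. It offers no direction for methoxy to hydroxy. No step beyond the scatter is therefore expected, and the range is kept wide for lack of direct evidence.

The estimated step is a 1.3-fold higher number from compound 3 to compound 4 (0.11 log units; within the scatter). Compound 4 is expected at 22000 nM, with an estimated range of 9000 nM to 55000 nM.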

Compound 4, half-maximal inhibitory concentration: 22900 nM
Beside the measured number, compound 4's estimate is 1.0-fold (0.02 log units) below it; low and high end bracket the measured number.
By their numbers in this assay, from the lowest: compounds 3, 4, 1 and 2 (each within the scatter of the next, the first and the last beyond it).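

In this assay, among these compounds, hydrogen in place of methyl on an oxygen on an aromatic ring, or methoxy to hydroxy, gives a 1.3-fold higher number from compound 3 to compound 4 (0.12 log units; within the scatter) and is the first single-place change read at this position. The loss of the methyl, with its one heavy atom, leaves the read-out within the scatter, so this pair gives no sign that the methyl on this oxygen matters for antiproliferative activity on this read-out. That makes two single-place changes within the scatter, the other being a 1.3-fold higher number from compound 1 to compound 2 (0.12 log units; within the scatter) at the sulfonyl sulfur, but they sit at different places and neither gives a direction for the other. Nothing at hand bears on why methoxy and hydroxy read alike here.

Going by these compounds, only methyl and hydrogen are seen on this oxygen, so it remains open whether an ethyl group, a longer chain ending in an amine or one ending in a carboxylic acid would give a step beyond the scatter. Also open is whether the same change would read alike with a different group on the sulfonyl sulfur, since the pair shown carries only one such group.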